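The source may report more compounds than this note shows. Statements on the series, on what has been measured and on what is new or still open speak of the compounds shown alone.

Measured compounds:
compound 1 `CC(C)C(c1ccc(-c2ccc3cccc(F)c3c2)[nH]c1=O)N1CCCCS1(=O)=O` — 0.373 h
compound 2 `CC(C)C(c1ncc[nH]1)c1ccc(-c2ccc3cccc(F)c3c2)[nH]c1=O` — a limit of < 0.0667 h, not a number

Both readings come from an ADME assay on microsomes from liver (Homo sapiens) for metabolic stability; on this read-out higher numbers stand for a longer-lived compound and lower numbers for a shorter-lived compound. Among the compounds with values here, compound 1 gives 0.373 h, the only actual number here. The reading for compound 2 sits at the limit of this assay the limit of < 0.0667 h in this assay, at which 1 of the 2 values shown sits, and gives no number. Within the data shown here, the one step measured, an at least 5.5-fold lower number from compound 1 to compound 2 (0.74 log units; beyond the scatter), runs from the sultam-bearing compound 1 to the imidazole-bearing compound 2 and marks a clear loss of stability.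

The unmeasured compound 3 `CC(C)C(/C=C1/CCNC1=O)c1ccc(-c2ccc3cccc(F)c3c2)[nH]c1=O` changes compound 1 at the same place: a group of 7 heavy atoms (5 carbon, 1 nitrogen, 1 oxygen; one five-membered non-aromatic ring with 1 hetero atom) in place of a group of 8 heavy atoms (4 carbon, 1 nitrogen, 2 oxygen, 1 sulfur; one six-membered non-aromatic ring with 2 hetero atoms), on a saturated chain carbon bound to an aromatic carbon and a saturated chain carbon. The entering group is a five-membered non-aromatic ring with one hetero atom carrying one hydrogen-bond donor and one acceptor, replacing the six-membered non-aromatic ring with two hetero atoms. Among the measured compounds shown here, the only guidance is the step to compound 2, where swapping the same sultam away cost stability beyond the scatter. That step concerns a different replacement, so it is taken as a sign of direction rather than size. Compound 3 is therefore expected to fall short of compound 1, by a step of a 2.1-fold lower number from compound 1 to compound 3 (0.32 log units; beyond the scatter), and its half-life in this assay is estimated at 0.18 h, within 0.06 h to 0.5 h.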

Compound 3, half-life: 0.987 h
Compound 3: middle estimate off by 5.5-fold (0.74 log units), on the low side; measured number outside the range, above it.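

In this assay the five-membered non-aromatic ring with 1 hetero atom gives a 2.6-fold higher number from compound 1 to compound 3 (0.42 log units; beyond the scatter) and so shows that, on a saturated chain carbon bound to an aromatic carbon and a saturated chain carbon, giving up the six-membered non-aromatic ring with 2 hetero atoms need not shorten the half-life. With an at least 14-fold higher number from compound 2 to compound 3 (1.17 log units; beyond the scatter) in the same assay, the two replacements part widely, and the outcome at this place turns on which group enters, not merely on the loss of the six-membered ring. The size of that second step rests on compound 2, whose reading is a limit and not a number: the limit of < 0.0667 h in this assay, at which 1 of the 3 values shown sits.

The compounds shown do not tell which feature of the entering group goes with the longer half-life, whether its ring size, its hydrogen-bond donor or its double bonds outside aromatic rings. On these data alone, how an open-chain amide, an amine or a carboxylic acid would read on this same carbon remains open, as does whether any such group would match or pass compound 3.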